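Growth inhibition notes: from compound 2 to compound 3

The compounds below may be only part of what the source reports. "The series", "measured", "known", "first", "only" and "open" are said of these compounds alone.

In an ADME assay on HeLa cells (Homo sapiens) for inhibition, read by MTT assay, with a stated time of 60 h (on this read-out higher numbers stand for weaker inhibition of growth and lower numbers for stronger inhibition of growth), compound 1 `O=C(c1ccccc1)n1cc(-c2ccccc2)c(-c2ccccc2)c1` gives 67100 nM.

Compound 2 `COc1ccc(C(=O)n2cc(-c3ccc(OC)cc3)c(-c3ccc(OC)cc3)c2)cc1` reads > 100000 nM, which is a limit of the assay and not a number. Its standing in the series is summed up as the limit of > 100000 nM in this assay, at which 1 of the 2 values shown sits.

Compound 3 `COc1ccc(/C=C/C(=O)n2cc(-c3ccc(OC)cc3)c(-c3ccc(OC)cc3)c2)cc1` has 2-(4-methoxyphenyl)ethenyl in place of 4-methoxyphenyl on a carbonyl carbon.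

For the measured compounds named here, no measured step between single-site analogues is available, so the expectation in this assay rests on few data. Going by the values given here, the only number so far, 67100 nM for compound 1, suggests that any activity here is likely to remain weak. A modest shift towards stronger inhibition of growth is expected, and the estimated step is an at least 2.0-fold lower number from compound 2 to compound 3 (0.30 log units; that floor lies within the scatter). For compound 3 the estimated value is 50000 nM, with an expected range from 12000 nM to 100000 nM.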

Compound 3, concentration for 50% growth inhibition: > 100000 nM
Compound 3 gave a limit, no number; the forecaster's own chance of this, stated with the estimate: 35%; middle value at least 2.0-fold (0.30 log units) away from the limit.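

For the compounds shown here, compound 2 and compound 3 each give only a limit in this assay, not a number, and no step between them can be read. The compounds shown leave open whether 2-(4-methoxyphenyl)ethenyl in place of 4-methoxyphenyl on a carbonyl carbon changes growth inhibition at all.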